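Chloro for nitro in a two-compound series

The compounds below may be only part of what the source reports. "The series", "measured", "known", "first", "only" and "open" are said of these compounds alone.

Compound 1 `COc1cccc(Nc2nc(Nc3cc(C)[nH]n3)cc(N3CCN(C)CC3)n2)c1` gives 546 nM
Compound 2 `Cc1cc(Nc2cc(N3CCN(C)CC3)nc(Nc3cccc([N+](=O)[O-])c3)n2)n[nH]1` gives 1110 nM
Compound 3 `Cc1cc(Nc2cc(N3CCN(C)CC3)nc(Nc3cccc(Cl)c3)n2)n[nH]1` has no value yet

All of these numbers come from a functional assay on HeLa cells (Homo sapiens) for antiproliferative activity, read by CCK-8 assay, with a stated time of 72 h (a lower number here means a stronger inhibitor, a higher number a weaker inhibitor), and nothing else. Within the data shown here, compound 2 holds the higher of the two measured numbers, and its only neighbour, compound 1, sits lower.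

Compound 3 differs from compound 2 at a single place: chloro in place of nitro on an aromatic carbon and in words, chloro in place of nitro on an aromatic carbon, meta to a large group.

Among the measured compounds shown here, only one measured step bears on this change. It is a 2.0-fold higher number from compound 1 to compound 2 (0.31 log units; beyond the scatter) and it was modest, with nitro in place of methoxy on an aromatic carbon. That step shows nitro entering, whereas here nitro leaves. For the measured compounds named here, no chloro compound has been measured, so the direction rests on this one comparison and the size is uncertain. A modest move towards a lower number is expected, and the estimated step is a 1.5-fold lower number from compound 2 to compound 3 (0.17 log units; within the scatter) in this assay at most a small shift.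

For compound 3 the expected value is 750 nM with an estimated range from 320 nM to 1600 nM in this read-out.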

Compound 3, half-maximal inhibitory concentration: 425 nM
For compound 3 the middle estimate is 1.8-fold (0.25 log units) above the measured one; measured number inside the range.
By their numbers in this assay, from the lowest: compounds 3 and 1 (each within the scatter of the next); then compound 2.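

At this position, an aromatic carbon meta to a large group, the swap of nitro for chloro can now be read directly: in this assay it gives a 2.6-fold lower number from compound 2 to compound 3 (0.42 log units; beyond the scatter) and this step lies beyond the usual scatter. Replacing methoxy with chloro at the same place gives a 1.3-fold lower number from compound 1 to compound 3 (0.11 log units; within the scatter) and this step stays within the scatter, so chloro and methoxy cannot be told apart in this read-out. Among the three groups shown here, nitro alone stands apart from both of the others, which the earlier pair could not show, as it held only one comparison and no chloro compound. Nothing given here accounts for these differences.

The compounds shown leave open whether this pattern extends to other groups at this place, such as fluoro, a nitrile, an amine or a carboxylic acid. They also leave open how chloro would read on a different carbon of the same ring, or with the methylpiperazine-free parts of the core changed, since all three compounds share everything except this single group.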